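From Compound 2 to Compound 4 in Receptor Binding

A few compounds are considered here, and "the series" means these few. Any claim that something is new, unique, unknown or untested is made for them only; others in the source may bear on it.

Of the compounds shown here, three sharing one core have been tested in an assay on HEK293 cells for displacement of a labelled ligand from melanin-concentrating hormone receptor 1 (Homo sapiens); a lower number here means a stronger inhibitor, a higher number a weaker inhibitor. Compound 1 `COc1ccc(OC2CN(C(=O)NC3CCN(Cc4ccn(-c5ccc(C(F)(F)F)cc5)c4)CC3)C2)cc1` gives 49 nM in this assay. Compound 2 `O=C(NC1CCN(Cc2ccn(-c3ccc(C(F)(F)F)cc3)c2)CC1)N1CCCC1Cc1cccnc1` gives 26 nM, and compound 3 `O=C(NC[C@@H]1CCCC[C@H]1O)NC1CCN(Cc2ccn(-c3ccc(C(F)(F)F)cc3)c2)CC1` gives 46 nM. Compound 2 carries the lowest of these three numbers, but the gaps are small: the step of a 1.8-fold higher number from compound 2 to compound 3 (0.25 log units; within the scatter) stays within the scatter, and the number of compound 1 differs from that of compound 2 by a similarly small margin.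

Compound 4 `O=C(O)CC(NC(=O)NC1CCN(Cc2ccn(-c3ccc(C(F)(F)F)cc3)c2)CC1)c1ccccc1` has not yet been measured. It differs from compound 2 by (2-carboxy-1-phenylethyl)amino in place of 2-((pyridin-3-yl)methyl)pyrrolidin-1-yl on a carbonyl carbon. Among the measured compounds shown here, only one measured step bears on this kind of change: the step of a 1.8-fold higher number from compound 2 to compound 3 (0.25 log units; within the scatter), in which the same group on the carbonyl carbon was replaced by another amino-type substituent, and the number hardly moved. On that basis, the replacement in compound 4 is expected to produce no step beyond the scatter, with perhaps a slight drift toward a higher number. The step of a 1.5-fold higher number from compound 2 to compound 4 (0.19 log units; within the scatter) is therefore estimated to be small. Compound 4 is expected to give about 40 nM in this assay, with a range from 15 nM to 120 nM.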

Compound 4, half-maximal inhibitory concentration: 412 nM
Compound 4: the middle estimate sits 10-fold (1.01 log units) below what was measured; the whole stated range lies below it.
By their numbers in this assay, from the lowest: compounds 2, 3 and 1 (each within the scatter of the next); then compound 4.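

In this assay the group on the carbonyl carbon proves not to be freely exchangeable: a 16-fold higher number from compound 2 to compound 4 (1.20 log units; beyond the scatter) lies beyond the scatter, while the earlier replacement a 1.8-fold higher number from compound 2 to compound 3 (0.25 log units; within the scatter) stayed within it, so two amino-type groups at this place can give clearly different outcomes. The (2-carboxy-1-phenylethyl)amino group also separates from the substituent of compound 3, with a 9.0-fold higher number from compound 3 to compound 4 (0.95 log units; beyond the scatter) beyond the scatter, and the leaving and entering groups of the change from compound 2 hold the same count of heavy atoms, so that count alone does not set the number here. Nothing among the data shown gives a measured reason for this rise.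

The compounds shown leave open whether the step belongs to the carboxy group, to the phenyl ring or to the two together, as both enter in a single change. A methyl ester or a primary carboxamide in place of the carboxylic acid on the same chain would separate these parts, and so would a simple benzylamino group carrying no chain at all.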